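Cyclobutyl for phenyl on the aminoquinoline amide series

This account rests on a few compounds, and the source may have more. Where it says the series, first, only, none or still open, it means among the compounds named here.

Two compounds of the series carry a number in a functional assay on HEK293 cells for activation of melanin-concentrating hormone receptor 1 (Homo sapiens), read by inositol phosphate accumulation; on this read-out lower numbers stand for an effect already at smaller amounts and higher numbers for an effect only at larger amounts of compound. Compound 1 `CCCc1cc(N)c2cc(NC(=O)c3ccc(-c4ccc(Cl)cc4)cc3)ccc2n1` gives 75 nM. Compound 2 `Nc1cc(-c2ccccc2)nc2ccc(NC(=O)/C=C/c3ccc(C(F)(F)F)cc3)cc12` gives 6600 nM, which is the higher of the two numbers; the nearest neighbour is compound 1, and the gap between the two values lies beyond the scatter. Within the data shown here, the two structures differ in several places at once, so no single step between them can be told.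

Compound 3 `Nc1cc(C2CCC2)nc2ccc(NC(=O)/C=C/c3ccc(C(F)(F)F)cc3)cc12` has not yet been measured in this assay. Relative to compound 2 it differs in one place: cyclobutyl in place of phenyl on an aromatic carbon. Among the measured compounds shown here, no measured pair shows a step of this kind, so the expectation rests on compound 2 alone and is set close to its value.

The change from compound 2 to compound 3 is expected to be small in this assay, within the scatter, with a slight lean toward a lower number, as a 1.3-fold lower number from compound 2 to compound 3 (0.12 log units; within the scatter) states. For compound 3 the estimated value in this assay is 5000 nM, within a range from 1500 nM to 16000 nM.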

Compound 3, half-maximal effective concentration: 250 nM
Compound 3: middle estimate off by 20-fold (1.30 log units), on the high side; measured number below the stated range.
By their numbers in this assay, from the lowest: compound 1; then compound 3; then compound 2.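

In this assay, the aromatic carbon next to the ring nitrogen proves sensitive to the group it carries: cyclobutyl in place of phenyl gives a 26-fold lower number from compound 2 to compound 3 (1.42 log units; beyond the scatter), a large step on an otherwise unchanged structure. Among these compounds, compound 1 and compound 2 differ in several places at once, so this pair gives the first single-place reading at this position. The change replaces a six-membered aromatic ring of 6 heavy atoms with a four-membered non-aromatic ring of 4 heavy atoms, and no measurement at hand separates these two differences or explains the step.

Still open, on these data alone, is how the number responds at this carbon to other groups, such as cyclopropyl, cyclohexyl, an open chain such as isopropyl, or an amine such as piperidine, which would help show whether ring size, aromatic character or something else tracks with the step. Also open, as far as these compounds go, is whether the same exchange has a similar effect with the amide portion of compound 1, since the step is so far known only with the trifluoromethyl-substituted cinnamide of compound 2 and compound 3.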